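Ethyl for ethoxy on compound 3

The source may report more compounds than this note shows. Statements on the series, on what has been measured and on what is new or still open speak of the compounds shown alone.

Compound 3 `CCOc1ncc(-c2nc(C(F)(F)F)sc2N2CCN(C(=O)Cn3nc(C)nc3C)[C@H](C)C2)cn1` gives 7 nM in a functional assay on CHO-K1 cells for antagonist activity at C-X-C chemokine receptor type 3 (Homo sapiens), read by FLIPR, with a stated time of 10 min; on this read-out lower numbers stand for stronger inhibition and higher numbers for weaker inhibition; that is the highest of the three numbers, yet compound 2 `CCOc1ncc(-c2nc(C(F)(F)F)sc2N2CCN(C(=O)Cn3ncc4cccnc43)[C@H](C)C2)cn1` with 4.1 nM and compound 1 `CCOc1ncc(-c2nc(C(F)(F)F)sc2N2CCN(C(=O)Cn3ccc4cnccc43)[C@H](C)C2)cn1` with 3.6 nM both lie within the scatter of it, as a 1.9-fold higher number from compound 1 to compound 3 (0.29 log units; within the scatter) and a 1.7-fold higher number from compound 2 to compound 3 (0.23 log units; within the scatter) show, and a 1.1-fold higher number from compound 1 to compound 2 (0.06 log units; within the scatter) also stays within the scatter. Compound 4 `CCc1ncc(-c2nc(C(F)(F)F)sc2N2CCN(C(=O)Cn3nc(C)nc3C)[C@H](C)C2)cn1` carries ethyl in place of ethoxy on an aromatic carbon, that is 2-ethoxypyrimidin-5-yl becoming 2-ethylpyrimidin-5-yl. For the measured compounds named here, none of the measured steps touches this place; all three vary the group on the saturated chain carbon bound to a carbonyl carbon, so no measured step bears on the change. Compound 4 is therefore expected to give 10 nM in this assay, within a range of 4 nM to 30 nM, a step of a 1.4-fold higher number from compound 3 to compound 4 (0.15 log units; within the scatter) that is not expected to exceed the scatter.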

Compound 4, half-maximal inhibitory concentration: 14 nM
Beside the measured number, compound 4's estimate is 1.4-fold (0.15 log units) below it, and the stated range covers the measured number.
By their numbers in this assay, from the lowest: compounds 1, 2, 3 and 4 (each within the scatter of the next, the first and the last beyond it).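

For the compounds shown here, the step from 2-ethoxypyrimidin-5-yl to 2-ethylpyrimidin-5-yl is the first measured at this position and reads a 2.0-fold higher number from compound 3 to compound 4 (0.30 log units; within the scatter) in this assay. With the rest of compound 3 held constant, the ethoxy oxygen and its hydrogen-bond acceptor can therefore be absent without a step beyond the scatter. Nothing available explains the size of this step. Going by these compounds, whether the same change reads alike with the amide side groups of compound 1 and compound 2 remains open. So does the effect of a methoxy group, a propyl chain or an amine on this aromatic carbon.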